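A few compounds are considered here, and "the series" means these few. Any claim that something is new, unique, unknown or untested is made for them only; others in the source may bear on it.

Measured compounds:
- compound 1, `O=C(O)COCCCC[C@H]1[C@H](F)CC[C@@H]1NS(=O)(=O)c1ccc(F)cc1F`, in a functional assay on a cell-free system (plasma) for inhibition of thromboxane A2 receptor (Homo sapiens), read by turbidimetry (on this read-out higher numbers stand for weaker inhibition and lower numbers for stronger inhibition), gives 1800 nM
- compound 2, `O=C(O)CCC/C=C\CC1=CCC[C@@H]1NS(=O)(=O)c1ccccc1`, in this assay gives 2300 nM
- compound 3, `Cc1ccc(S(=O)(=O)N[C@H]2CCC=C2CCCCOCC(=O)O)cc1`, in this assay gives 1900 nM

Compound 1 shows the lowest of the three numbers, but its distance to compound 3 and to compound 2 is within the usual scatter of repeated measurements, so the three compounds cannot be placed in an order on these data; they sit in the same region of the read-out.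

Compound 4, `O=C(O)COCCCC[C@H]1[C@H](F)CC[C@@H]1NS(=O)(=O)c1ccccc1`, is drawn from compound 1 by one change: phenyl in place of 2,4-difluorophenyl on a sulfonyl sulfur. Going by the values given here, no step between two measured compounds is available for this change. What the measured set does show is that compound 2, which also carries a plain phenyl on its sulfonyl sulfur, and compound 3 give numbers within the scatter of compound 1. On that basis the step from compound 1 to compound 4 is expected to stay within the scatter, with no clear direction, and the estimated step is a 1.2-fold higher number from compound 1 to compound 4 (0.09 log units; within the scatter). Compound 4 is therefore expected to give about 2200 nM in this assay, with a range from 1000 nM to 4800 nM.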

Compound 4, half-maximal inhibitory concentration: 1700 nM
Estimate against measurement, compound 4: 1.3-fold (0.11 log units) above; low and high end bracket the measured number.
By their numbers in this assay, from the lowest: compounds 4, 1, 3 and 2 (each within the scatter of the next).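

Going by these compounds alone, the first direct step at this position, phenyl in place of 2,4-difluorophenyl on a sulfonyl sulfur, gives a 1.1-fold lower number from compound 1 to compound 4 (0.02 log units; within the scatter) in this assay, and this lies within the scatter. Within the data shown here, on the core of compound 1, then, the two fluorine atoms of the leaving group can be given up without a change that this read-out can resolve, which the earlier compounds could only hint at since they differ from one another in more than one place. Nothing shown offers an explanation for this outcome.

Going by these compounds, whether any group on the sulfonyl sulfur can move the number beyond the scatter stays open. A naphthyl, a pyridyl or a 4-methoxyphenyl group in this place, for example, would test how far this tolerance extends on the same core.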